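Toward Compound 4: Swapping the Nitrogen-Rich Side Chain for Isopropyl

This account rests on a few compounds, and the source may have more. Where it says the series, first, only, none or still open, it means among the compounds named here.

Three compounds have been measured so far:
compound 1, `C[C@@H](O)[C@H](NC(=O)CN(c1nc(Cl)nc2[nH]cnc12)C1CC1)C(=O)O`, with 24%;
compound 2, `O=C(CN(c1nc(Cl)nc2[nH]cnc12)C1CC1)N[C@@H](CO)C(=O)O`, with 18.8%;
compound 3, `N=C(N)NCCC[C@H](NC(=O)CN(c1nc(Cl)nc2[nH]cnc12)C1CC1)C(=O)O`, with 7.19%.

All three share a core and differ only in the group on a saturated chain carbon bound to an amide-type nitrogen and a carbonyl carbon. In a functional assay on the whole organism (Tail, strain ICR) with Mus musculus as the target, in the tail flick test, with a stated time of 150 min, at a dose of 25 umol/kg by the oral route (a higher number here means a stronger effect of the compound at the dose given, a lower number a weaker effect), compound 3 stands lowest of the three: the step of a number 16.8 percentage points lower from compound 1 to compound 3 (beyond the scatter) and the step of a number 11.6 percentage points lower from compound 2 to compound 3 (beyond the scatter) both lie beyond the scatter, while a number 5.2 percentage points lower from compound 1 to compound 2 (within the scatter) does not.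

Compound 4, `CC(C)[C@H](NC(=O)CN(c1nc(Cl)nc2[nH]cnc12)C1CC1)C(=O)O`, is not yet measured. It differs from compound 3 in that (a group of 3 heavy atoms (3 carbon; no ring) in place of a group of 7 heavy atoms (4 carbon, 3 nitrogen; no ring), on a saturated chain carbon bound to an amide-type nitrogen and a carbonyl carbon). The two steps that bear on this are the ones into compound 3, each removing a small group and adding the larger nitrogen-rich group with a modest loss. Reversing that direction with an isopropyl suggests a modest rise, expected to be on the order of those steps; compound 4 is therefore expected to give 20%, between 8% and 32%, which means an expected step of a number 12.8 percentage points higher from compound 3 to compound 4 (beyond the scatter).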

Compound 4, a percentage reported as activity, at one dose (the size of the read-out at that dose, not a potency): 7.86%
Compound 4: middle estimate off by 12.1 percentage points, on the high side, and the stated range ends above it.
By their numbers in this assay, from the lowest: compounds 3 and 4 (each within the scatter of the next); then compounds 2 and 1 (each within the scatter of the next).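

In this assay, isopropyl in place of the group of 7 heavy atoms gives a number 0.7 percentage points higher from compound 3 to compound 4 (within the scatter), so the low reading of compound 3 cannot be tied to its nitrogen-rich group in particular. Isopropyl in place of hydroxymethyl gives a number 10.9 percentage points lower from compound 2 to compound 4 (beyond the scatter), and in place of 1-hydroxyethyl it gives a number 16.1 percentage points lower from compound 1 to compound 4 (beyond the scatter): among these four compounds, the two with a hydroxyl-bearing group at this place stand apart from the two without one, and no compound goes against this. Nothing available explains this split.

The compounds shown leave open how a simple amine, a carboxylic acid or a phenyl ring would read at this place, and whether a longer chain ending in a hydroxyl would stay level with compound 1. They also leave open whether this split holds at other doses or times.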